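The source may report more compounds than this note shows. Statements on the series, on what has been measured and on what is new or still open speak of the compounds shown alone.

Among the three measured compounds, compound 3 `CCc1cc(C)c(C(=O)N=C(N)N)cc1S(C)(=O)=O` stands lowest in a functional assay for inhibition of sodium/hydrogen exchanger (Oryctolagus cuniculus); on this read-out higher numbers stand for weaker inhibition and lower numbers for stronger inhibition: compound 3 gives 4.8 nM. Compound 1 `CCc1cc(Cl)c(S(C)(=O)=O)cc1C(=O)N=C(N)N` gives 63 nM and compound 2 `CS(=O)(=O)c1cc(C(=O)N=C(N)N)c(Cl)cc1Cl` gives 140 nM, both well beyond the scatter from the number of compound 3. For the measured compounds named here, the only single-point step among them is a 2.2-fold higher number from compound 1 to compound 2 (0.35 log units; beyond the scatter), a modest weakening when chloro takes the place of ethyl on an aromatic carbon.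

Compound 4 `Cc1cc(-c2ccc(Cl)cc2)c(S(C)(=O)=O)cc1C(=O)N=C(N)N` differs from compound 3 by 4-chlorophenyl in place of ethyl on an aromatic carbon. Going by the values given here, no measured step exchanges ethyl for an aryl group, so the change has no close precedent here; the one step that removes an ethyl group, from compound 1 to compound 2, went towards a weaker inhibition by a modest amount. On that slender basis a modest weakening is expected, of the size a 3.1-fold higher number from compound 3 to compound 4 (0.49 log units; beyond the scatter), with the real possibility that the number hardly moves. Compound 4 is therefore expected to give 15 nM, within a range from 4 nM to 60 nM.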

Compound 4, half-maximal inhibitory concentration: 45 nM
Beside the measured number, compound 4's estimate is 3.0-fold (0.48 log units) below it; the range from low to high includes it.
By their numbers in this assay, from the lowest: compound 3; then compounds 4 and 1 (each within the scatter of the next); then compound 2.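

Placing 4-chlorophenyl on this aromatic carbon, ortho to a methylsulfonyl group, gives a 9.4-fold higher number from compound 3 to compound 4 (0.97 log units; beyond the scatter) in this assay. For the compounds shown here, this is the first aromatic ring seen at this position, and it shows that the position accepts a much larger group than ethyl at a measurable cost while inhibition is retained: compound 4 still gives 45 nM on this read-out. Going by these compounds alone, the step also gives the first direct reading of how far inhibition moves when ethyl is exchanged for an aryl group on this core.

The compounds shown leave open whether the weakening comes from the ring itself or from its chlorine, which an unsubstituted phenyl group would help to separate. They also leave open how a methoxy group or an amine would fare at this position. No evidence at hand accounts for the size of this step.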